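This account rests on a few compounds, and the source may have more. Where it says the series, first, only, none or still open, it means among the compounds named here.

Working notes on three compounds sharing one core: compound 1 `CSc1ncnc2c1c(-c1cccs1)cn2[C@@H]1O[C@H](CO)[C@@H](O)[C@H]1O`, compound 2 `CNc1ncnc2c1c(-c1ccoc1)cn2[C@@H]1O[C@H](CO)[C@@H](O)[C@H]1O` and the still unmeasured compound 3 `CNc1ncnc2c1c(-c1cccs1)cn2[C@@H]1O[C@H](CO)[C@@H](O)[C@H]1O`. In a functional assay on K562 cells (Homo sapiens), read by MTT assay, with a stated time of 72 h (a higher number here means a weaker inhibitor, a lower number a stronger inhibitor), compound 1 gives 11600 nM. Compound 2 gives > 20000 nM, which is a limit of the assay and not a number, so compound 2 has no exact position in the series. Among the compounds with values here, compound 1 and compound 2 differ in more than one place, so their values yield no single-change step. Compound 3 carries thiophen-2-yl in place of furan-3-yl on an aromatic carbon. A modest gain in this assay, towards a lower number, is expected because compound 1 with the same thiophen-2-yl gives 11600 nM. The expected step runs an at least 2.2-fold lower number from compound 2 to compound 3 (0.34 log units; beyond the scatter), and its size stays uncertain. For compound 3 the estimated value is 9000 nM, with an expected range of 2500 nM to 20000 nM.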

Compound 3, half-maximal inhibitory concentration: > 20000 nM
Compound 3 was reported as a limit (the forecaster's own chance of this, stated with the estimate: 35%); at least 2.2-fold (0.34 log units) between middle value and limit.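

In this assay compound 3 gives > 20000 nM as a limit of the assay and not a number. Within the data shown here, with thiophen-2-yl held constant, methylamino in place of methylsulfanyl on an aromatic carbon gives an at least 1.7-fold higher number from compound 1 to compound 3 (0.23 log units; that floor lies within the scatter) and thus provides the first single-change comparison, although its floor alone does not separate the two compounds. The step for thiophen-2-yl in place of furan-3-yl cannot be read, since both compounds stand at the same assay limit: the limit of > 20000 nM in this assay, at which 2 of the 3 values shown sit.

As far as these compounds go, how far compound 2 and compound 3 lie beyond that limit remains open, as does the true size of the methylamino change. Also open, from the compounds shown here alone, is whether a dimethylamino group or a longer alkylthio chain in that place, or a phenyl ring on the aromatic carbon, would give a value within the assay's range.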